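Chain extension on an ester tail: from decyl toward octadecyl

The compounds below may be only part of what the source reports. "The series", "measured", "known", "first", "only" and "open" are said of these compounds alone.

Measured compounds:
compound 1 `CCOC(=O)CCC(=O)N1CCN(CCCOc2cc3c(Nc4ccc(F)c(Cl)c4)ncnc3cc2OC)CC1`, 35.6% in a functional assay on A549 cells (Homo sapiens) for cytotoxicity, read by MTT assay, with a stated time of 24 h, tested at 80 uM; a lower number here means a stronger effect, a higher number a weaker effect of the compound at the concentration tested
compound 2 `CCCCCCCCCCOC(=O)CCC(=O)N1CCN(CCCOc2cc3c(Nc4ccc(F)c(Cl)c4)ncnc3cc2OC)CC1`, 2%

Within the data shown here, compound 2 stands lowest of the two numbers measured so far; its nearest neighbour is compound 1, which sits well above it, and the gap is beyond the scatter. Among the measured compounds shown here, the single measured step, a number 33.6 percentage points lower from compound 1 to compound 2 (beyond the scatter), was large and downward. Compound 3 `CCCCCCCCCCCCCCCCCCOC(=O)CCC(=O)N1CCN(CCCOc2cc3c(Nc4ccc(F)c(Cl)c4)ncnc3cc2OC)CC1` is the next member of the series, differing from compound 2 by octyl in place of hydrogen on a saturated chain carbon, ten or more bonds along the chain from an oxygen next to a carbonyl group. The earlier step shows that lengthening this tail once gave a large drop, so it is the step that bears here. However, compound 2 already reads close to the floor of the read-out, so there is little room for a further drop of comparable size. Compound 3 is therefore expected to give a step of a number 1 percentage points higher from compound 2 to compound 3 (within the scatter), which lies within the scatter. The estimate for compound 3 is 3%, ranging from 0% to 13%.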

Compound 3, a percentage reported as activity, at one concentration (the size of the read-out at that concentration, not a potency): 86.7%
The estimate for compound 3 lay 83.7 percentage points below the measured number; measured number outside the range, above it.
By their numbers in this assay, from the lowest: compound 2; then compound 1; then compound 3.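

In this assay, octyl in place of hydrogen on a saturated chain carbon, ten or more bonds along the chain from an oxygen next to a carbonyl group, gave a number 84.7 percentage points higher from compound 2 to compound 3 (beyond the scatter). That runs opposite to a number 33.6 percentage points lower from compound 1 to compound 2 (beyond the scatter), where the same group stood two bonds along the chain from that oxygen, so across these three compounds the effect of lengthening the tail does not run in one direction. Nothing available here accounts for this reversal.

The compounds shown leave open whether a dodecyl or tetradecyl ester would read closer to compound 2 or to compound 3, and so where along the chain the turn comes. They also leave open how a carboxylic acid in place of the ester would read.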